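The source may hold more compounds than are shown below. What is called first, only, known or untested is meant among the compounds shown, and "the series" means these compounds.

Measured compounds:
compound 1 `COC(=O)C[C@H](NC(=O)OC(C)(C)C)C(=O)N(Cc1ccc(F)cc1)C1(C(=O)NCc2ccccc2)CCN(c2ccccc2)CC1` with 20000 nM
compound 2 `CCC(C)N(C(=O)[C@H](CC(=O)OC)NC(=O)OC(C)(C)C)C1(C(=O)NCc2ccccc2)CCN(Cc2ccccc2)CC1` with 84000 nM

In an ADME assay on MDCK cells (Canis lupus familiaris) for cytotoxicity, read by microscopy, with a stated time of 72 h (a lower number here means that less compound is tolerated, a higher number that more compound is tolerated), compound 2 gives 84000 nM, the higher of the two numbers recorded, and compound 1 gives 20000 nM, a gap beyond the usual scatter. Compound 3 `COC(=O)C[C@H](NC(=O)OC(C)(C)C)C(=O)N(Cc1ccccc1F)C1(C(=O)NCc2ccccc2)CCN(Cc2ccccc2)CC1` has not been measured in this assay. It differs from compound 2 in one place: 2-fluorobenzyl in place of sec-butyl on an amide-type nitrogen. Since compound 1 carries a benzyl-type group on the same amide-type nitrogen and gives 20000 nM, compound 3 is expected to fall below compound 2, with the step from compound 2 to compound 3 estimated at a 2.8-fold lower number from compound 2 to compound 3 (0.45 log units; beyond the scatter). Compound 3 is therefore estimated at 30000 nM, within a range from 10000 nM to 80000 nM.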

Compound 3, minimum cytotoxic concentration: 20000 nM
Compound 3: middle estimate off by 1.5-fold (0.18 log units), on the high side; low and high end bracket the measured number.
By their numbers in this assay, from the lowest: compounds 1 and 3 (each within the scatter of the next); then compound 2.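

In this assay, within the data shown here, putting 2-fluorobenzyl in place of sec-butyl on the amide-type nitrogen gives a 4.2-fold lower number from compound 2 to compound 3 (0.62 log units; beyond the scatter), the first comparison in which only this position changes. It shows that the group on this nitrogen can, by itself, shift the minimum cytotoxic concentration, with 2-fluorobenzyl on the lower side of this pair. No measurement shown offers an explanation for the step. On these data alone, it remains open whether unsubstituted benzyl would give a similar number, which would help separate the contribution of the ring from that of the fluorine. A cyclohexyl group at this position is also untested here.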